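This account rests on a few compounds, and the source may have more. Where it says the series, first, only, none or still open, it means among the compounds named here.

Among the measured compounds shown here, in an assay for inhibition of Pro-cathepsin H (Homo sapiens), read by fluorescence, tested at 50 uM (on this read-out lower numbers stand for less inhibition and higher numbers for more inhibition at the one concentration tested (going by the name of the read-out)), two compounds have numbers so far. Compound 1 `COc1nc(OC)nc(Sc2ccccc2C(=O)N[C@@H](C)C(=O)OCc2ccccc2)n1` gives 1.34% in this assay. Compound 2 `CC(C)(C)c1ccccc1Nc1nc(Cl)nc(Cl)n1` gives -4.16% in this assay, which places it at the bottom of the two numbers, though the gap to compound 1 lies within the usual scatter of such measurements, so the two cannot really be told apart: both sit close to no inhibition at all.

Compound 3 `CCc1ccccc1Nc1nc(Cl)nc(Cl)n1` still awaits measurement. It differs from compound 2 in one place: ethyl in place of tert-butyl on an aromatic carbon. For the measured compounds named here, no pair of measured compounds shows what a change of this kind does here, and the two measured numbers themselves sit near zero, so no step beyond the scatter is expected in either direction. The expected step is a number 2.2 percentage points higher from compound 2 to compound 3 (within the scatter). Compound 3 is therefore estimated to give -2% in this assay, within a range from -12% to 8%.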

Compound 3, a percentage reported as inhibition, at one concentration (the size of the read-out at that concentration, not a potency): -2.26%
The estimate for compound 3 lay 0.3 percentage points above the measured number; the measured number falls inside the stated range.
By their numbers in this assay, from the lowest: compounds 2, 3 and 1 (each within the scatter of the next).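

Among the compounds shown here, replacing tert-butyl with ethyl on this aromatic carbon, ortho to a group of 9 heavy atoms, gives the first step that can be read at this position: in this assay it is a number 1.9 percentage points higher from compound 2 to compound 3 (within the scatter) for this change. Going from the 4 heavy atoms of tert-butyl to the 2 of ethyl therefore leaves no difference that can be told from the scatter, so this pair gives no sign that the size of this alkyl group matters here. Nothing available explains this result.

Going by these compounds, whether a group of another kind at this position, such as an amine, a carboxylic acid or a longer chain, would produce a step beyond the scatter remains open. On these data alone, it is also open whether replacing a chlorine on the shared core with an amine would change the reading.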